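The compounds below may be only part of what the source reports. "The series", "measured", "known", "first", "only" and "open" are said of these compounds alone.

Compound 1 `Clc1ccc(/C=N/c2sc3c(c2-c2nc4ccccc4s2)CCC3)cc1` gives 342 ug/mL in an ADME assay on cells (Rhabdomyosarcoma cell, Homo sapiens) for cytotoxicity, read by MTT assay, with a stated time of 72 h; on this read-out higher numbers stand for lower toxicity in this test and lower numbers for higher toxicity in this test. Compound 2 `Clc1ccc(/C=N/c2sc3c(c2-c2nc4ccccc4s2)CCC3)c(Cl)c1` carries one more chlorine on its phenyl ring chloro in place of hydrogen on an aromatic carbon and gives 160 ug/mL; this change made a 2.1-fold lower number from compound 1 to compound 2 (0.33 log units; beyond the scatter). Compound 3 `Oc1ccccc1/C=N/c1sc2c(c1-c1nc3ccccc3s1)CCC2` differs from compound 1 in its core (2-hydroxyphenyl in place of 4-chlorophenyl on a carbon with a double bond to nitrogen). Compound 3 gives 100 ug/mL, a change of a 3.4-fold lower number from compound 1 to compound 3 (0.53 log units; beyond the scatter); against compound 2 the result is a 1.6-fold lower number from compound 2 to compound 3 (0.20 log units; within the scatter).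

Compound 4 `Oc1ccccc1/C=N/c1sc2c(c1-c1nc3cc(Cl)ccc3s1)CCC2` is not yet measured. It carries the chloro in place of hydrogen on an aromatic carbon, the same kind of change as that from compound 1 to compound 2 but not the same: there the chlorine entered ortho to a large group and meta to a chloro group, whereas here it enters a ring that is part of a fused or bridged system of two rings, meta to a fused ring and para to a fused ring. Because the earlier change gave a 2.1-fold lower number from compound 1 to compound 2 (0.33 log units; beyond the scatter), a modest lowering is expected again, and compound 4 is estimated at 60 ug/mL in this assay, a range of 30 ug/mL to 120 ug/mL, which means an expected step of a 1.7-fold lower number from compound 3 to compound 4 (0.22 log units; within the scatter).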

Compound 4, half-maximal cytotoxic concentration: 269 ug/mL
Estimate against measurement, compound 4: 4.5-fold (0.65 log units) below; measured number above the stated range.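

The step of a 2.7-fold higher number from compound 3 to compound 4 (0.43 log units; beyond the scatter) runs the opposite way to the earlier one, so in this assay the change of hydrogen to chloro did not keep its direction from one core to the other: the same change on two cores in this assay, a 2.1-fold lower number (0.33 log units; beyond the scatter) from compound 1 to compound 2 and a 2.7-fold higher number (0.43 log units; beyond the scatter) from compound 3 to compound 4, 5.7-fold (0.76 log units) apart, beyond the scatter of two such steps.

This does not show that the core alone decides the outcome, as the chlorine entered the phenyl ring in compound 2 but a ring that is part of a fused system in compound 4, so core and place change together. Among these compounds, with only one pair on each side, the series gives no rule for other places on these rings and no reason why the two steps part.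

The compounds shown leave open how a chloro on the 2-hydroxyphenyl ring of compound 3 would act, and how the chloro of compound 4 would act on the core of compound 1. They also leave open what a methoxy group or an amine would do in place of that hydroxyl group.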